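This account rests on a few compounds, and the source may have more. Where it says the series, first, only, none or still open, it means among the compounds named here.

Measured compounds in an assay for displacement of a labelled ligand from Nicotinic acetylcholine receptor alpha8 subunit (Periplaneta americana), read by scintillation counting, with a stated time of 2 h, at 24 degrees C, tested at 10 uM; a higher number here means more inhibition at the concentration tested (going by the name of the read-out), a lower number less inhibition:

Compound 1 `Oc1cccc(/C=C2\CCN=C2c2cccnc2)c1`: 32.1%
Compound 2 `COc1ccc(/C=C2\CCN=C2c2cccnc2)cc1`: 31.4%
Compound 3 `Fc1ccc(/C=C2\CCN=C2c2cccnc2)cc1`: 22.3%

Compound 3 carries the lowest of the three numbers in this assay. Its nearest neighbour is compound 2, whose value stands higher, and the furthest is compound 1, whose value stands higher still; both gaps lie within the scatter, so the three compounds cannot be ordered against one another on these numbers. Going by the values given here, the only step between two compounds that differ in one place is a number 9.1 percentage points lower from compound 2 to compound 3 (within the scatter), and it too stays within the scatter.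

Compound 4 `N#Cc1ccc(/C=C2\CCN=C2c2cccnc2)cc1` is to be measured in this assay. It differs from compound 3 as follows: cyano in place of fluoro on an aromatic carbon. Among the compounds with values here, no measured step involves a cyano group, and the single step that does exist, from a methoxy to a fluoro substituent, carried no change beyond the scatter. There is therefore nothing in the data to suggest that cyano in place of fluoro on an aromatic carbon should move the read-out by a notable amount in either direction, and the expected step is a number 2.7 percentage points higher from compound 3 to compound 4 (within the scatter), a change that stays within the scatter. On that basis compound 4 is estimated to give 25% in this assay, with a range from 10% to 40%.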

Compound 4, a percentage reported as inhibition, at one concentration (the size of the read-out at that concentration, not a potency): 31.4%
For compound 4 the middle estimate is 6.4 percentage points below the measured one; the range from low to high includes it.
By their numbers in this assay, from the lowest: compounds 3, 2, 4 and 1 (each within the scatter of the next).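

In this assay, this aromatic carbon, para to a large group, now carries a third substituent, and cyano in place of fluoro gives a number 9.1 percentage points higher from compound 3 to compound 4 (within the scatter) while cyano in place of methoxy gives no change at the digits printed from compound 2 to compound 4 (within the scatter) on the same carbon. The cyano group adds a triple bond and a hydrogen-bond acceptor, neither of which fluoro has, yet no step among the three compounds with a single substituent at this place goes beyond the scatter, so the change has not yet shown that the read-out depends on the group here. No other measurement is available that could explain this behaviour at this position.

On these data alone, what an amine, a carboxylic acid or a longer chain would do on this aromatic carbon stays open, as does whether any group here can give a step beyond the scatter. Compound 1 differs from the others in more than one place, so the contribution of its hydroxy group cannot be separated from these steps.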